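The source may hold more compounds than are shown below. What is called first, only, known or untested is meant among the compounds shown, and "the series" means these compounds.

Three compounds have been measured in a functional assay on a cell-free system (plasma, Oryctolagus cuniculus) for inhibition, with stated times of 5 min, 1 min and 6 min; on this read-out lower numbers stand for stronger inhibition and higher numbers for weaker inhibition:

Compound 1 `C=CCOn1c(-c2cccc(C#N)c2)nc(C)c1C(=O)OCC`: 5860 nM
Compound 2 `CCOC(=O)c1c(C)nc(-c2cccc(C#N)c2)n1OCc1ccncc1`: 6200 nM
Compound 3 `CCOC(=O)c1c(C)nc(-c2cccc(C#N)c2)n1OCc1ccc([N+](=O)[O-])cc1`: 8750 nM

Compound 1 stands at the low end of these three numbers, yet the steps of a 1.1-fold higher number from compound 1 to compound 2 (0.02 log units; within the scatter) and a 1.5-fold higher number from compound 1 to compound 3 (0.17 log units; within the scatter) both lie within the scatter, as does a 1.4-fold higher number from compound 2 to compound 3 (0.15 log units; within the scatter). Compound 4 `CCOC(=O)c1c(C)nc(-c2cccc(C#N)c2)n1OCc1ccc(C#N)cc1` has not been measured; it differs from compound 1 by 4-cyanophenyl in place of vinyl on a saturated chain carbon bound to an oxygen on an aromatic ring. The two measured steps that bear on this change each replace vinyl at the same place with a different group, and both moved the number only within the scatter, so no step beyond the scatter is expected in this assay for compound 4 either. Compound 4 is therefore estimated at 7000 nM, from 3500 nM to 14000 nM, an expected step of a 1.2-fold higher number from compound 1 to compound 4 (0.08 log units; within the scatter).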

Compound 4, half-maximal inhibitory concentration: 4240 nM
Estimate against measurement, compound 4: 1.7-fold (0.22 log units) above; low and high end bracket the measured number.
By their numbers in this assay, from the lowest: compounds 4, 1, 2 and 3 (each within the scatter of the next, the first and the last beyond it).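

In this assay, the larger 4-cyanophenyl group at the end of the chain leaves the number within the scatter when it replaces vinyl (a 1.4-fold lower number from compound 1 to compound 4 (0.14 log units; within the scatter)) or pyridin-4-yl (a 1.5-fold lower number from compound 2 to compound 4 (0.17 log units; within the scatter)). Among the compounds shown here, the new information lies on the aromatic ring: cyano in place of nitro on an aromatic carbon gives the first step beyond the scatter here, though only a modest one (a 2.1-fold lower number from compound 3 to compound 4 (0.31 log units; beyond the scatter)). No available evidence accounts for this step. Still open, going by these compounds, is how an amine or a carboxylic acid on that aromatic carbon, or a longer chain in place of allyl, would read.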